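A few compounds are considered here, and "the series" means these few. Any claim that something is new, unique, unknown or untested is made for them only; others in the source may bear on it.

In a functional assay on HL-60 cells (Homo sapiens) for antiproliferative activity, with a stated time of 24 h (on this read-out lower numbers stand for stronger inhibition and higher numbers for weaker inhibition), the measured compounds are:

- Compound 1 `NC(=O)c1c(NC(=O)c2ccccc2Cl)sc2c1CCN(Cc1c(Cl)cccc1Cl)C2`: 4850 nM
- Compound 2 `NC(=O)c1c(NC(=O)c2ccccc2Cl)sc2c1CCN(Cc1ccc(Cl)cc1Cl)C2`: 8010 nM
- Compound 3 `NC(=O)c1c(NC(=O)c2ccccc2Cl)sc2c1CCN(Cc1cc(Cl)cc(Cl)c1)C2`: 15800 nM

These three compounds differ only in the dichlorophenyl group on a saturated chain carbon bound to an amine nitrogen in a ring. Compound 2 stands in the middle of the three numbers, though neither of its gaps leaves the scatter: a 1.7-fold higher number from compound 1 to compound 2 (0.22 log units; within the scatter), and a 2.0-fold higher number from compound 2 to compound 3 (0.30 log units; within the scatter). Only the outer pair separates, and modestly, with a 3.3-fold higher number from compound 1 to compound 3 (0.51 log units; beyond the scatter).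

Compound 4 `Cc1ccc(C(=O)Nc2sc3c(c2C(N)=O)CCN(Cc2ccc(Cl)cc2Cl)C3)cc1` keeps the 2,4-dichlorophenyl of compound 2 and changes the other end of the molecule: 4-methylphenyl in place of 2-chlorophenyl on a carbonyl carbon. In short, 4-methylphenyl stands in place of 2-chlorophenyl on a carbonyl carbon.

Going by the values given here, none of the measured steps touches this place, so the data give no direct measure of this change. The steps at the other site offer only a rough idea of scale, the largest being the modest one from compound 1 to compound 3. No shift beyond the scatter is therefore expected, although the uncertainty is wide. The estimated step is a 1.0-fold lower number from compound 2 to compound 4 (0.00 log units; within the scatter). For compound 4 the estimated value is 8000 nM, with an expected range of 2500 nM to 25000 nM.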

Compound 4, half-maximal inhibitory concentration: 19900 nM
For compound 4 the middle estimate is 2.5-fold (0.40 log units) below the measured one; low and high end bracket the measured number.
By their numbers in this assay, from the lowest: compounds 1, 2, 3 and 4 (each within the scatter of the next, the first and the last beyond it).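

In this assay, going by these compounds alone, the step of a 2.5-fold higher number from compound 2 to compound 4 (0.40 log units; beyond the scatter) gives the first measured change at this end of the molecule, and it shows that the group on a carbonyl carbon whose other neighbour is an amide-type nitrogen does affect the read-out, here toward weaker inhibition. The step is modest, the same grade as the largest step at the dichlorophenyl site, a 3.3-fold higher number from compound 1 to compound 3 (0.51 log units; beyond the scatter), so the two sites are of comparable standing on the evidence of these compounds. The two groups have matching counts of heavy atoms, hydrogen-bond donors and acceptors, and nothing available here accounts for the shift.

This single step replaces the chlorine with a methyl and also moves the substituent from the 2-position of the phenyl to the 4-position, so 2-methylphenyl, 4-chlorophenyl or plain phenyl on the same carbonyl would be needed to separate those two changes. Going by these compounds, it also remains open whether the step would carry over to the 2,6-dichlorophenyl of compound 1, and how an amine or a carboxylic acid on this phenyl ring would read.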